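Esterifying a Free Hydroxy in a Macrocyclic Diterpenoid Series

The compounds below may be only part of what the source reports. "The series", "measured", "known", "first", "only" and "open" are said of these compounds alone.

Compound 2 `C=C1[C@H](OC(C)=O)[C@@H](OC(C)=O)[C@@H](OC(C)=O)C(C)(C)/C=C/[C@H](C)[C@H](OC(=O)c2ccccc2)[C@@]2(O)C[C@@](C)(O)[C@H](OC(C)=O)[C@@H]2[C@H]1OCC(C)C` is a heavily acetylated macrocycle with one free hydroxy on a saturated carbon. In a functional assay on NCI/ADR-RES cells (Homo sapiens) for positive allosteric modulation, read by MTT assay, with a stated time of 48 h, tested at 10 uM (a higher number here means a weaker inhibitor, a lower number a stronger inhibitor), compound 2 gives 13000 nM, the highest of the two numbers measured here, with compound 3 as its nearest neighbour. Compound 1 `C=C1[C@H](OC(C)=O)[C@@H](OC(C)=O)[C@@H](O)C(C)(C)/C=C/[C@H](C)[C@H](OC(=O)c2ccccc2)[C@@]2(O)C[C@@](C)(O)[C@H](OC(C)=O)[C@@H]2[C@H]1OCC(C)C` in this assay reaches only the limit > 100000 nM. Compound 3 `C=C1[C@H](OC(C)=O)[C@@H](OC(=O)c2cccc(C)c2)[C@@H](OC(C)=O)C(C)(C)/C=C/[C@H](C)[C@H](OC(=O)c2ccccc2)[C@@]2(O)C[C@@](C)(O)[C@H](OC(C)=O)[C@@H]2[C@H]1OCC(C)C` gives 980 nM. For the measured compounds named here, two measured steps bear on the change to compound 4 `C=C1[C@H](OC(C)=O)[C@@H](OC(C)=O)[C@@H](OC(C)=O)C(C)(C)/C=C/[C@H](C)[C@H](OC(=O)c2ccccc2)[C@@]2(O)C[C@@](C)(OC(=O)c3cccc(C)c3)[C@H](OC(C)=O)[C@@H]2[C@H]1OCC(C)C`: an at least 7.6-fold lower number from compound 1 to compound 2 (0.88 log units; beyond the scatter) shows what capping a free hydroxy did, and a 13-fold lower number from compound 2 to compound 3 (1.12 log units; beyond the scatter) shows what swapping a methyl for a 3-methylphenyl on a carbonyl did. The change to compound 4 is (3-methylphenyl)carbonyl in place of hydrogen on an oxygen on a saturated carbon, which combines both ideas at a different hydroxy. Taken together these steps make a lower number for compound 4 the expectation, and the step of a 5.2-fold lower number from compound 2 to compound 4 (0.72 log units; beyond the scatter) is the estimated size. Compound 4 is therefore expected to give about 2500 nM, plausibly between 600 nM and 10000 nM.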

Compound 4, half-maximal inhibitory concentration: 1510 nM
Beside the measured number, compound 4's estimate is 1.7-fold (0.22 log units) above it, within the range that was stated.
By their numbers in this assay, from the lowest: compounds 3 and 4 (each within the scatter of the next); then compound 2. At a limit, above all of these: compound 1.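

The earlier steps shown here touched other oxygens of the shared core, whereas this one shows that the hydroxy on this saturated carbon does not have to stay free. In this assay, replacing its hydrogen with (3-methylphenyl)carbonyl gives an 8.6-fold lower number from compound 2 to compound 4 (0.93 log units; beyond the scatter), so a large ester is accepted at this oxygen and goes with a stronger result. Nothing measured here explains why the number falls.

The compounds shown cannot separate the effect of capping the hydroxy from the effect of the added aromatic ring, as no simple acetyl sits at this oxygen. On these data alone, it also remains open how this position would respond to an ester carrying an amine, a carboxylic acid or a longer chain in place of the 3-methylphenyl group.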